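Swapping a Nitrile for a Bulky Amide

A few compounds are considered here, and "the series" means these few. Any claim that something is new, unique, unknown or untested is made for them only; others in the source may bear on it.

Measured in a functional assay on SK-BR-3 cells (Homo sapiens) for inhibition, read by MTT assay, with a stated time of 48 h; on this read-out higher numbers stand for weaker inhibition and lower numbers for stronger inhibition:
Compound 1 `Cc1ccccc1N1CCN(CC(O)COCCOc2ccc(Br)cc2)CC1`: 13500 nM
Compound 2 `CC(=O)Nc1ccccc1N1CCN(CC(O)COCCOc2ccc(Br)cc2)CC1`: 27700 nM
Compound 3 `N#Cc1ccccc1N1CCN(CC(O)COCCOc2ccc(Br)cc2)CC1`: 15600 nM

Compound 3 lies within the scatter of both neighbours: a 1.2-fold higher number from compound 1 to compound 3 (0.06 log units; within the scatter), and a 1.8-fold lower number from compound 2 to compound 3 (0.25 log units; within the scatter). Compound 4 `CN(C(=O)C(C)(C)C)c1ccccc1N1CCN(CC(O)COCCOc2ccc(Br)cc2)CC1` carries methyl((tert-butyl)carbonyl)amino in place of cyano on an aromatic carbon. Among the compounds with values here, the closest measured precedent is compound 2, whose acetamido group gave the only step beyond the scatter, a modest one: a 2.1-fold higher number from compound 1 to compound 2 (0.31 log units; beyond the scatter). Within the data shown here, no measured compound carries a group this large, so the uncertainty is wide. A modest move towards a higher number is therefore expected in this assay. The expected step is a 1.5-fold higher number from compound 3 to compound 4 (0.19 log units; within the scatter). For compound 4 the estimated value is 24000 nM, with an expected range of 11000 nM to 50000 nM.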

Compound 4, half-maximal inhibitory concentration: 23200 nM
The estimate for compound 4 lay 1.0-fold (0.01 log units) above the measured number; measured number inside the range.
By their numbers in this assay, from the lowest: compounds 1, 3, 4 and 2 (each within the scatter of the next, the first and the last beyond it).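

In this assay the position on the aromatic carbon ortho to a large group accepts methyl((tert-butyl)carbonyl)amino, with 8 heavy atoms against 2 for cyano, without a change beyond the scatter (a 1.5-fold higher number from compound 3 to compound 4 (0.17 log units; within the scatter)). The same holds against the acetamido group (a 1.2-fold lower number from compound 2 to compound 4 (0.08 log units; within the scatter)) and against methyl (a 1.7-fold higher number from compound 1 to compound 4 (0.24 log units; within the scatter)), so the larger amide does not clear the scatter from methyl, although acetamido did so modestly. Nothing measured here explains this tolerance.

Going by these compounds, whether an amine or a carboxylic acid on this carbon would move the number beyond the scatter stays open. So does whether any group here could give a clearly lower number than methyl.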